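The source may hold more compounds than are shown below. What is called first, only, known or untested is meant among the compounds shown, and "the series" means these compounds.

For the measured compounds named here, compound 1 `CC1CCN(c2c(S(=O)(=O)c3ccccc3)cnc3ccc(F)cc23)CC1` gives 40% in an assay on isolated protein for displacement of a labelled ligand from metabotropic glutamate receptor 5 (Homo sapiens), with a stated time of 60 min, tested at 1 uM (a higher number here means more inhibition at the concentration tested (going by the name of the read-out), a lower number less inhibition), the lowest of the three numbers known. Compound 2 `CC1CCN(c2c(S(=O)(=O)c3ccccc3)cnc3ccc(Cl)cc23)CC1` gives 59% and compound 3 `CC1CCN(c2c(S(=O)(=O)c3ccccc3)cnc3ccccc23)CC1` gives 89.2%; the steps of a number 19 percentage points higher from compound 1 to compound 2 (beyond the scatter) and a number 49.2 percentage points higher from compound 1 to compound 3 (beyond the scatter) both concern the halogen on the shared core, as does a number 30.2 percentage points higher from compound 2 to compound 3 (beyond the scatter). Compound 4 `CC1CCN(c2c(S(=O)(=O)c3ccc(C#N)cc3)cnc3ccc(F)cc23)CC1` differs from compound 1 elsewhere: cyano in place of hydrogen on an aromatic carbon, with the fluoro of compound 1 kept. Going by the values given here, no measured step touches this part of the molecule, so the measured steps give no guide to the direction of this change, and no step beyond the scatter is expected. The estimate for compound 4 in this assay is 40%, between 18% and 65%, an expected step of no change at the digits printed from compound 1 to compound 4 (within the scatter).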

Compound 4, a percentage reported as inhibition, at one concentration (the size of the read-out at that concentration, not a potency): 75%
For compound 4 the middle estimate is 35 percentage points below the measured one, and the stated range ends below it.
By their numbers in this assay, from the lowest: compound 1; then compound 2; then compound 4; then compound 3.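

In this assay, phenyl to 4-cyanophenyl gives a number 35 percentage points higher from compound 1 to compound 4 (beyond the scatter), the first step shown away from the halogen on the shared core. It shows that this ring position, para to a large group, is not silent: with the fluoro kept, cyano in place of hydrogen carries a large step upward. The compounds shown leave open whether an amine or a carboxylic acid at this position would move the number the same way, and whether the cyano step holds with hydrogen in place of fluoro on the core. Nothing available explains this step.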